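A series held at its limit, and compound 4

The compounds below may be only part of what the source reports. "The series", "measured", "known", "first", "only" and "open" are said of these compounds alone.

Measured so far in a functional assay on cells (leukaemia cell line, Homo sapiens) for inhibition, read by sulforhodamine B assay, with a stated time of 48 h (a higher number here means that more compound is tolerated, a lower number that less compound is tolerated), as limits and not as numbers
Compound 1 `O=S(=O)(Nc1ccc(F)c(Cl)c1)c1ccc(-c2cnc(C3CC3)o2)cc1` gives > 100000 nM as a limit
Compound 2 `O=S(=O)(Nc1cccc(Cl)c1)c1ccc(-c2cnc(C3CC3)o2)cc1` gives > 100000 nM as a limit
Compound 3 `O=S(=O)(Nc1ccc(Br)c(Cl)c1)c1ccc(-c2cnc(C3CC3)o2)cc1` gives > 100000 nM as a limit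

Compound 3 thus holds only a limit and no number, like the other two compounds, as the limit of > 100000 nM in this assay, at which 3 of the 3 values shown sit, sums up. Compound 4 `O=S(=O)(Nc1cc(F)cc(F)c1)c1ccc(-c2cnc(C3CC3)o2)cc1` brings 3,5-difluorophenyl in place of 4-bromo-3-chlorophenyl on a sulfonamide nitrogen with 3,5-difluorophenyl in place of 4-bromo-3-chlorophenyl on a sulfonamide nitrogen. The measured steps that bear on this are a step that the two limits leave unreadable from compound 1 to compound 3 and a step that the two limits leave unreadable from compound 2 to compound 3 and a step that the two limits leave unreadable from compound 1 to compound 2 and none of them has a size. No step beyond the scatter is therefore expected in this assay and the estimated change is a number no higher from compound 3 to compound 4 (the limit leaves the size open) in no particular direction. For compound 4 the expected value is 100000 nM with an estimated range from 50000 nM to 200000 nM and a report as a limit is likely.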

Compound 4, concentration lethal to 50% of the cells: > 100000 nM
Compound 4: no number, only a limit; the forecaster's own chance of this, stated with the estimate: 90%; the middle value lies on the limit itself.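

Among the compounds shown here, compound 4, like compound 1, compound 2 and compound 3, is reported in this assay only as a limit, so no step to compound 4 can be read. The compounds shown leave open whether the group on the sulfonamide nitrogen changes the read-out at all: the limit of > 100000 nM in this assay, at which 4 of the 4 values shown sit.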